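Replacing the hydroxyethyl urea tail of compound 3 with an aryl

A few compounds are considered here, and "the series" means these few. Any claim that something is new, unique, unknown or untested is made for them only; others in the source may bear on it.

Measured so far:
compound 1, `COc1ccc(C(=NNC(=O)NNC(=O)NCCCC(C)Nc2cc(OC)cc3cccnc23)c2ccc(OC)cc2)cc1`: 7500 nM
compound 2, `O=C1NCCN1C(c1ccccc1)(c1ccccc1)c1ccccc1`: 68000 nM
compound 3, `COc1cc(NC(C)CCCNC(=O)NNC(=O)N(CCO)CCO)c2ncccc2c1`: a limit only

In a functional assay on L1210 cells (Mus musculus) for inhibition, read by MTT assay, with a stated time of 4 days (on this read-out lower numbers stand for stronger inhibition and higher numbers for weaker inhibition), compound 1 gives 7500 nM, and compound 2 gives 68000 nM. Compound 3 gives no number in this assay but only a limit, > 250000 nM. That limit is the limit of > 250000 nM in this assay, at which 1 of the 3 values shown sits. Compound 4, `COc1cc(NC(C)CCCNC(=O)Nc2ccc(Cl)c(C(F)(F)F)c2)c2ncccc2c1`, keeps the core of compound 3 and differs from it at a single place: 4-chloro-3-(trifluoromethyl)phenyl in place of (bis(2-hydroxyethyl)carbamoyl)amino on an amide-type nitrogen. Going by the values given here, no step between two measured compounds is known here, so nothing measured tells how far such a change moves this assay. Compound 4 is nevertheless expected to give a number rather than a limit, a step of an at least 16-fold lower number from compound 3 to compound 4 (1.22 log units; beyond the scatter) toward stronger inhibition. For compound 4 the estimated value in this assay is 15000 nM, expected to fall between 2500 nM and 120000 nM.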

Compound 4, half-maximal inhibitory concentration: 3600 nM
Estimate against measurement, compound 4: 4.2-fold (0.62 log units) above, and the stated range covers the measured number.
By their numbers in this assay, from the lowest: compound 4; then compound 1; then compound 2. At a limit, above all of these: compound 3.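

At this amide-type nitrogen, this assay shows an at least 69-fold lower number from compound 3 to compound 4 (1.84 log units; beyond the scatter), with 4-chloro-3-(trifluoromethyl)phenyl in place of (bis(2-hydroxyethyl)carbamoyl)amino. The group at this one place can therefore take the shared core from a limit to a measured number. The true size of the step stays open on one side, as compound 3 stands only at a limit: the limit of > 250000 nM in this assay, at which 1 of the 4 values shown sits.

The compounds shown leave open whether the aromatic ring alone or its chloro and trifluoromethyl groups carry the step, which a plain phenyl would help separate. They also leave open how a carboxylic acid or an amine on that ring would read.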